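Quinazoline urea-hydrazones: phenyl swap on the methoxy core

A few compounds are considered here, and "the series" means these few. Any claim that something is new, unique, unknown or untested is made for them only; others in the source may bear on it.

Measured so far:
compound 1 `O=C(N/N=C/c1cc(Br)c(O)c(Br)c1)Nc1cc2c(Nc3ccc(F)c(Cl)c3)ncnc2cc1O[C@H]1CCOC1` gives 6160 nM
compound 2 `O=C(N/N=C/c1ccc(O)cc1O)Nc1cc2c(Nc3ccc(F)c(Cl)c3)ncnc2cc1O[C@H]1CCOC1` gives 7540 nM
compound 3 `COc1cc2ncnc(Nc3ccc(F)c(Cl)c3)c2cc1NC(=O)N/N=C/c1cc(Br)c(O)c(Br)c1` gives 41500 nM

All three numbers come from a functional assay on PC-3 cells (Homo sapiens) for cytotoxicity, read by MTT assay, with a stated time of 72 h; a lower number here means a stronger inhibitor, a higher number a weaker inhibitor. Compound 1 and compound 2 share one core and differ only in the aryl group on the hydrazone carbon: 2,4-dihydroxyphenyl in place of 3,5-dibromo-4-hydroxyphenyl on a carbon with a double bond to nitrogen. The step reads a 1.2-fold higher number from compound 1 to compound 2 (0.09 log units; within the scatter), so the two values are not told apart here. Within the data shown here, compound 3 carries the other core; the difference from compound 1 is methyl in place of oxolan-3-yl on an oxygen on an aromatic ring, and this step is a 6.7-fold higher number from compound 1 to compound 3 (0.83 log units; beyond the scatter), the only change of the three that moves beyond the scatter.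

Compound 4 `COc1cc2ncnc(Nc3ccc(F)c(Cl)c3)c2cc1NC(=O)N/N=C/c1ccc(O)cc1O` has not been measured. It stands to compound 3 as compound 2 stands to compound 1: 2,4-dihydroxyphenyl in place of 3,5-dibromo-4-hydroxyphenyl on a carbon with a double bond to nitrogen. The place of the change is the same, word for word, on both cores, so this is the same change made a second time.

In this assay the step is expected to read a 1.2-fold higher number from compound 3 to compound 4 (0.08 log units; within the scatter); this rests on compound 1 and compound 2, where the same change gave a 1.2-fold higher number from compound 1 to compound 2 (0.09 log units; within the scatter). Compound 4 is therefore estimated at 50000 nM, with the likely range between 20000 nM and 120000 nM.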

Compound 4, half-maximal inhibitory concentration: 29500 nM
Compound 4: middle estimate off by 1.7-fold (0.23 log units), on the high side, and the stated range covers the measured number.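

Carrying 2,4-dihydroxyphenyl in place of 3,5-dibromo-4-hydroxyphenyl onto the second core gives a 1.4-fold lower number from compound 3 to compound 4 (0.15 log units; within the scatter) in this assay, so this swap is not resolved on either core, and the two steps agree: the same change on two cores in this assay, a 1.2-fold higher number (0.09 log units; within the scatter) from compound 1 to compound 2 and a 1.4-fold lower number (0.15 log units; within the scatter) from compound 3 to compound 4, 1.7-fold (0.24 log units) apart, within the scatter of two such steps

The exchange of oxolan-3-yl for methyl on the aromatic oxygen, read on the 2,4-dihydroxyphenyl compounds, gives a 3.9-fold higher number from compound 2 to compound 4 (0.59 log units; beyond the scatter), in the same direction as the step on the 3,5-dibromo-4-hydroxyphenyl pair and of a size that carries over: the same change on two cores in this assay, a 6.7-fold higher number (0.83 log units; beyond the scatter) from compound 1 to compound 3 and a 3.9-fold higher number (0.59 log units; beyond the scatter) from compound 2 to compound 4, 1.7-fold (0.24 log units) apart, within the scatter of two such steps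

These four compounds thus show the two changes behaving independently in this assay, but they form a single square, and steps within the scatter cannot exclude a small real difference from the aryl swap.

Still open, as far as these compounds go, is how other groups on that oxygen would read, such as an ethyl group or a longer chain ending in an amine. Also open, from the compounds shown here alone, is whether an aryl group carrying a carboxylic acid would keep the same agreement between the two cores.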